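The source may report more compounds than this note shows. Statements on the series, on what has been measured and on what is new or still open speak of the compounds shown alone.

Measured so far in an in vitro assay on CHO cells for displacement of a labelled ligand from Bombesin receptor subtype-3 (Homo sapiens), read by scintillation counting, with a stated time of 2 h; on this read-out lower numbers stand for stronger inhibition and higher numbers for weaker inhibition:
compound 1 `CCC(C)(C)Cc1c[nH]c(CCc2ccc(-c3cccc(N)n3)cc2)n1` gives 7.3 nM
compound 2 `CCC(C)(C)Cc1c[nH]c(CCc2ccc(-c3csnn3)cc2)n1` gives 45 nM
compound 3 `CCC(C)(C)Cc1c[nH]c(CCc2ccc(-c3cccnc3)cc2)n1` gives 7.5 nM

Compound 3 stands second highest of these three numbers, practically level with compound 1 (a 1.0-fold higher number from compound 1 to compound 3 (0.01 log units; within the scatter)) and well apart from compound 2 (a 6.0-fold lower number from compound 2 to compound 3 (0.78 log units; beyond the scatter)). Compound 4 `CCC(C)(C)Cc1c[nH]c(CCc2ccc(N3CCCCC3)cc2)n1` differs from compound 3 in one place: piperidin-1-yl in place of pyridin-3-yl on an aromatic carbon. Within the data shown here, none of the measured steps bears directly on this change: all three swap one aromatic ring for another, whereas here a non-aromatic ring enters. Those steps show that the group at this position shifts the number by a modest amount at most, as in a 6.2-fold higher number from compound 1 to compound 2 (0.79 log units; beyond the scatter). Among the measured compounds shown here, with no direct precedent, a modest weakening is expected for compound 4, a 2.7-fold higher number from compound 3 to compound 4 (0.43 log units; beyond the scatter), giving an estimate of 20 nM with a range from 5 nM to 80 nM.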

Compound 4, half-maximal inhibitory concentration: 28 nM
For compound 4 the middle estimate is 1.4-fold (0.15 log units) below the measured one; low and high end bracket the measured number.
By their numbers in this assay, from the lowest: compounds 1 and 3 (each within the scatter of the next); then compounds 4 and 2 (each within the scatter of the next).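

Replacing an aromatic ring with a non-aromatic one at this position costs some inhibition, with (a 3.7-fold higher number from compound 3 to compound 4 (0.57 log units; beyond the scatter)) and (a 3.8-fold higher number from compound 1 to compound 4 (0.58 log units; beyond the scatter)) both beyond the scatter. Compound 4 nevertheless stays within the scatter of the 1,2,3-thiadiazol-4-yl compound (a 1.6-fold lower number from compound 2 to compound 4 (0.21 log units; within the scatter)), so the non-aromatic ring is tolerated here and not every aromatic ring outperforms it. No evidence at hand explains these differences. Still open, as far as these compounds go, is how other non-aromatic rings, such as morpholine or pyrrolidine, would behave at this place. An open-chain amine such as diethylamino is equally unexplored here.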